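Diisopropylcarbamoyl on the ring carbon of compound 3

A few compounds are considered here, and "the series" means these few. Any claim that something is new, unique, unknown or untested is made for them only; others in the source may bear on it.

Measured so far in a functional assay on MCF7 cells (Homo sapiens) for antiproliferative activity, read by MTT assay, with a stated time of 48 h (on this read-out higher numbers stand for weaker inhibition and lower numbers for stronger inhibition), as follows:
compound 1 `CC(C)=CCC[C@]1(C)/C=C/[C@@H](OC(=O)C=C(C)C)[C@](C)(O)/C=C/C(=O)/C(CN(C)C)=C\C1` gives 690 nM
compound 2 `CC(C)=CCC[C@]1(C)/C=C/[C@@H](OC(=O)C=C(C)C)[C@](C)(O)/C=C/C(=O)/C(Cn2cc(CO)nn2)=C\C1` gives 2930 nM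
compound 3 `CO/N=C/C1=C/C[C@](C)(CCC=C(C)C)/C=C/[C@@H](OC(=O)C=C(C)C)[C@](C)(O)/C=C/C1=O` gives 2510 nM

Compound 3 (2510 nM) stands level with compound 2, the gap being a 1.2-fold lower number from compound 2 to compound 3 (0.07 log units; within the scatter) and lying within the scatter. Compound 1 stands apart from the pair, with a 3.6-fold higher number from compound 1 to compound 3 (0.56 log units; beyond the scatter) and a 4.2-fold higher number from compound 1 to compound 2 (0.63 log units; beyond the scatter) as modest steps beyond the scatter.

Compound 4 `CC(C)=CCC[C@]1(C)/C=C/[C@@H](OC(=O)C=C(C)C)[C@](C)(O)/C=C/C(=O)/C(C(=O)N(C(C)C)C(C)C)=C\C1` is reached from compound 3 by a group of 9 heavy atoms (7 carbon, 1 nitrogen, 1 oxygen; no ring) in place of a group of 4 heavy atoms (2 carbon, 1 nitrogen, 1 oxygen; no ring), on a double-bonded ring carbon in which diisopropylcarbamoyl enters on the double-bonded ring carbon. Only the dimethylamino compound, compound 1, gives a number apart from the others. Compound 4 lacks that group, as do compound 2 and compound 3. Among the compounds with values here, no measured compound carries diisopropylcarbamoyl, so the size of this group is untested in this assay and the range is kept wide, more so on the side of weaker inhibition. The comparison of compound 2 and compound 3 (a 1.2-fold lower number from compound 2 to compound 3 (0.07 log units; within the scatter)) is the closest guide, so no step beyond the scatter is expected.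

The expected step is a 1.1-fold higher number from compound 3 to compound 4 (0.05 log units; within the scatter) and remains an estimate. The estimated value for compound 4 is 2800 nM (expected range 1000 nM to 8000 nM).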

Compound 4, half-maximal inhibitory concentration: 17200 nM
Compound 4: middle estimate off by 6.1-fold (0.79 log units), on the low side; measured number outside the range, above it.
By their numbers in this assay, from the lowest: compound 1; then compounds 3 and 2 (each within the scatter of the next); then compound 4.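

In this assay the double-bonded ring carbon is not indifferent to its group even without dimethylamino: diisopropylcarbamoyl gives a 6.9-fold higher number from compound 3 to compound 4 (0.84 log units; beyond the scatter) and also a 5.9-fold higher number from compound 2 to compound 4 (0.77 log units; beyond the scatter) so the level shared by compound 2 and compound 3 does not hold for every replacement. The span at this position now reaches a 25-fold higher number from compound 1 to compound 4 (1.40 log units; beyond the scatter) and runs from (dimethylamino)methyl in compound 1 to diisopropylcarbamoyl in compound 4. No supporting data are available to account for these steps.

The compounds shown leave open whether the loss in compound 4 follows the two isopropyl groups or the carbamoyl itself, a question that dimethylcarbamoyl or a carboxylic acid on the same ring carbon would help to separate. Also open, going by these compounds, is whether the number of compound 1 is particular to (dimethylamino)methyl or is shared by other amines on the same saturated chain carbon, such as morpholin-4-ylmethyl or pyrrolidin-1-ylmethyl.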